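Allyl in Place of Isopropyl on the Amide Nitrogen

This account rests on a few compounds, and the source may have more. Where it says the series, first, only, none or still open, it means among the compounds named here.

Measured compounds:
compound 1, `CCN(C(=O)c1c(O)c2c(C)cccc2n(C)c1=O)c1ccccc1`, 65%
compound 2, `CCCN(C(=O)c1c(O)c2c(Cl)cccc2n(C)c1=O)c1ccccc1`, 94%
compound 3, `CC(C)N(C(=O)c1c(O)c2c(Cl)cccc2n(C)c1=O)c1ccccc1`, 54%

In a functional assay on the whole organism for inhibition, with Mus musculus as the target, at a dose of 1 mg/kg by the oral route (on this read-out lower numbers stand for less inhibition and higher numbers for more inhibition at the one dose given (going by the name of the read-out)), compound 3 gives 54% and stands lowest of the three measured values. Compound 1 lies nearest to it, and compound 2 lies furthest, with both gaps beyond the scatter. Among the compounds with values here, the only step that changes a single place is the one from propyl to isopropyl on the amide-type nitrogen, which brought a fall of a number 40 percentage points lower from compound 2 to compound 3 (beyond the scatter).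

Compound 4, `C=CCN(C(=O)c1c(O)c2c(Cl)cccc2n(C)c1=O)c1ccccc1`, differs from compound 3 by allyl in place of isopropyl on an amide-type nitrogen. Allyl, like propyl, is an unbranched chain of three carbon atoms, so this change undoes the branching that accompanied the large fall from compound 2 to compound 3. Within the data shown here, compound 4 is therefore expected to show a rise of a number 26 percentage points higher from compound 3 to compound 4 (beyond the scatter), though only one step informs this expectation and a full return to the level of compound 2 is not assured. For compound 4 the estimate in this assay is 80%, with a range from 55% to 96%.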

Compound 4, a percentage reported as inhibition, in the whole organism at one dose (the size of the read-out at that dose, not a potency): 59%
The estimate for compound 4 lay 21 percentage points above the measured number; the range from low to high includes it.
By their numbers in this assay, from the lowest: compounds 3, 4 and 1 (each within the scatter of the next, the first and the last beyond it); then compound 2.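

In this assay, allyl in place of isopropyl on the amide-type nitrogen gives a number 5 percentage points higher from compound 3 to compound 4 (within the scatter), so removing the branch from the three-carbon chain did not bring back the high number of compound 2. Vinyl in place of ethyl on the saturated chain carbon bound to the amide-type nitrogen gives a number 35 percentage points lower from compound 2 to compound 4 (beyond the scatter), which shows that an unbranched chain alone is not enough here and that, of the three groups on this nitrogen in the chlorinated series, only propyl carries the high number. Nothing at hand accounts for this result.

The compounds shown leave open whether a longer saturated chain such as butyl would hold the number that propyl gives. They also leave open how a chain ending in a methoxy group or an amine would fare at this nitrogen.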